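Removing a methoxy group from a sulfonamide aromatase series

The compounds below may be only part of what the source reports. "The series", "measured", "known", "first", "only" and "open" are said of these compounds alone.

Compound 1, `C[C@@H](c1ccc(Cl)cc1)N1Cc2cncn2C(CC2(C)COC2)S1(=O)=O`, gives 35% in an assay on isolated protein for inhibition of Aromatase (Homo sapiens), tested at 1 uM; a higher number here means more inhibition at the concentration tested (going by the name of the read-out), a lower number less inhibition.
Compound 2, `COC(C)(C)CC1n2cncc2CN([C@@H](C)c2ccc(Cl)cc2)S1(=O)=O`, gives 17% in this assay.
Compound 3, `CC(C)CC1n2cncc2CN(CC2CC2)S1(=O)=O`, gives 19% in this assay.

Compound 2 stands lowest of the three numbers, though compound 3 lies within the scatter of it; only compound 1 stands beyond. Compound 4, `CC(C)CC1n2cncc2CN([C@@H](C)c2ccc(Cl)cc2)S1(=O)=O`, differs from compound 2 by hydrogen in place of methoxy on a saturated chain carbon bound to three saturated chain carbons. Among the measured compounds shown here, the one measured step at this chain, a number 18 percentage points lower from compound 1 to compound 2 (beyond the scatter), swapped a different group and does not directly predict the loss of methoxy. Compound 3 already carries the isobutyl chain of compound 4, on a different nitrogen substituent, and sits within the scatter of compound 2. The step is therefore expected to stay within the scatter, a number 5 percentage points higher from compound 2 to compound 4 (within the scatter). Compound 4 is estimated at 22%, ranging from 5% to 40%.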

Compound 4, a percentage reported as inhibition, at one concentration (the size of the read-out at that concentration, not a potency): 56%
Compound 4: the middle estimate sits 34 percentage points below what was measured, outside the stated range (above it).
By their numbers in this assay, from the lowest: compounds 2 and 3 (each within the scatter of the next); then compound 1; then compound 4.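

In this assay, among the compounds shown here, hydrogen in place of methoxy on this saturated chain carbon gives a number 39 percentage points higher from compound 2 to compound 4 (beyond the scatter), so this position responds strongly to the change, which the earlier compounds did not reveal. The isopropyl group in place of 3-methyloxetan-3-yl gives a number 21 percentage points higher from compound 1 to compound 4 (beyond the scatter), placing the chain without oxygen above both oxygen-bearing chains. Nothing available explains this difference.

From the compounds shown here alone, whether a hydroxyl group or an amine on the same carbon would behave like methoxy or like hydrogen remains open. So does whether a longer chain would keep the higher number.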